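Pyrazole swap on the shared core of compound 1

The source may hold more compounds than are shown below. What is called first, only, known or untested is meant among the compounds shown, and "the series" means these compounds.

Compound 1 `Cc1ccc(NC(=O)c2cccc(C(F)(F)F)c2)cc1N1Cc2cnc(Nc3cnn(C)c3)nc2N(C)C1=O` is the reference point of this set. In an ADME assay on BaF3 cells (Mus musculus) for inhibition, read by CellTiter-Glo, with a stated time of 72 h (a lower number here means a stronger inhibitor of growth, a higher number a weaker inhibitor of growth), compound 1 gives 352 nM, the lowest of the three numbers, though every other value sits within the scatter of it. Going by the values given here, compound 2 `Cc1ccc(NC(=O)c2ccc(CN3CCC(N(C)C)C3)c(C(F)(F)F)c2)cc1N1Cc2cnc(Nc3cnn(C)c3)nc2N(C)C1=O` gives 414 nM, and the step of a 1.2-fold higher number from compound 1 to compound 2 (0.07 log units; within the scatter) is the only single-point change measured so far; it concerns an aromatic carbon on the amide side and not the heteroaryl amine. Compound 3 `Cc1ccc(Nc2ncc3c(n2)N(C2CC2)C(=O)N(c2cc(NC(=O)c4ccc(C)c(C(F)(F)F)c4)ccc2C)C3)cn1` gives 649 nM; it differs from compound 1 in more than one place, so its value shows only that a different heteroaryl amine on the shared core stays in the same range.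

Compound 4 `Cc1cc(Nc2ncc3c(n2)N(C)C(=O)N(c2cc(NC(=O)c4cccc(C(F)(F)F)c4)ccc2C)C3)n(C)n1` is not yet measured. Its change from compound 1 is 1,3-dimethyl-1H-pyrazol-5-yl in place of 1-methyl-1H-pyrazol-4-yl on a nitrogen on an aromatic ring. Among the compounds with values here, no measured step in this set touches that nitrogen on the aromatic ring, so there is no direct guide to the size of the effect. The values of compound 1 and compound 3 suggest that the heteroaryl amine can vary without a large shift, yet compound 4 keeps an otherwise identical core. A modest loss is expected, a 2.3-fold higher number from compound 1 to compound 4 (0.36 log units; beyond the scatter), with wide uncertainty. Compound 4 is estimated at 800 nM, within 250 nM to 2500 nM.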

Compound 4, concentration for 50% growth inhibition: 2060 nM
Beside the measured number, compound 4's estimate is 2.6-fold (0.41 log units) below it; the range from low to high includes it.
By their numbers in this assay, from the lowest: compounds 1, 2 and 3 (each within the scatter of the next); then compound 4.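

In this assay, going by these compounds alone, the step of a 5.9-fold higher number from compound 1 to compound 4 (0.77 log units; beyond the scatter) is the first measured change on this nitrogen on an aromatic ring, and it lies beyond the scatter, whereas the only earlier single-place step, a 1.2-fold higher number from compound 1 to compound 2 (0.07 log units; within the scatter) on the amide side, stays within it. The position is therefore sensitive to this exchange, even though 1-methyl-1H-pyrazol-4-yl and 1,3-dimethyl-1H-pyrazol-5-yl are both one five-membered aromatic ring with 2 hetero atoms and match in hydrogen-bond donors, hydrogen-bond acceptors and net charge, and differ by only one heavy atom. Nothing in hand links this step to a cause.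

The change moves the ring's attachment point and adds a methyl group in the same step, so the compounds shown do not separate the two, and 1-methyl-1H-pyrazol-5-yl or 1,3-dimethyl-1H-pyrazol-4-yl on the same nitrogen would be needed to assign the loss to one of them. Also open, going by these compounds, is whether a ring with a different substituent, such as a 1-ethyl-1H-pyrazol-4-yl group or a phenyl ring bearing a morpholine, would hold the number of compound 1 on the shared core.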